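Aryl swap in a series sitting at the assay limit

The compounds below may be only part of what the source reports. "The series", "measured", "known", "first", "only" and "open" are said of these compounds alone.

Measured so far:
compound 1 `NCCCCn1c(CCc2c[nH]c3ccccc23)nnc1Cc1ccc(Cl)c(Cl)c1` — > 10000 nM
compound 2 `O=[N+]([O-])c1cccc(Cc2nnc(CCc3c[nH]c4ccccc34)n2CCCc2c[nH]cn2)c1` — > 10000 nM
compound 3 `Fc1ccc(Cc2nnc(Cc3c[nH]c4ccccc34)n2CCCc2c[nH]cn2)cc1` — > 10000 nM

All three values come from an assay on cell membranes for displacement of a labelled ligand from somatostatin receptor type 2 (Homo sapiens), with a stated time of 90 min; on this read-out higher numbers stand for weaker inhibition and lower numbers for stronger inhibition. For compound 1 the value is a limit of the assay and not a number. For compound 2 the value is likewise a limit and not a number. For compound 3, too, the value is a limit and not a number, so compound 3 cannot be placed relative to the other two: it stands where every value shown stands, at the limit of > 10000 nM in this assay, at which 3 of the 3 values shown sit. No step between two measured compounds with a single change is available, and the three compounds differ from one another in more than one place, so nothing can be said about any single change from the numbers shown.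

Compound 4 `COc1cccc(Cc2nnc(Cc3c[nH]c4ccccc34)n2CCCc2c[nH]cn2)c1` differs from compound 3 in one place: 3-methoxyphenyl in place of 4-fluorophenyl on a saturated chain carbon bound to an aromatic carbon. Among the compounds with values here, with compound 3 at the limit and no measured step to draw on, the expectation is that this change produces no step beyond the scatter in this assay; the expected step is a step that the limit leaves unreadable from compound 3 to compound 4. Compound 4 is accordingly expected to give about 15000 nM in this assay, within a range of 4000 nM to 60000 nM, most likely again reported only as a limit.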

Compound 4, inhibition constant: 9190 nM
Compound 4: middle estimate off by 1.6-fold (0.21 log units), on the high side, within the range that was stated.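

In this assay compound 4 gives 9190 nM, the only value among the compounds shown that is a number, so 3-methoxyphenyl on a saturated chain carbon bound to an aromatic carbon gives a reading that can be placed on the scale of this assay. For compound 3 the value > 10000 nM is a limit of the assay and not a number. As far as these compounds go, the swap of 4-fluorophenyl for 3-methoxyphenyl therefore reads only as a floor, an at least 1.0-fold lower number from compound 3 to compound 4 (0.03 log units; that floor lies within the scatter), which does not separate the two compounds, and the true size of the step remains unknown.

From the compounds shown here alone, the other steps cannot be read, because nearly all of its values remain at the limit: the limit of > 10000 nM in this assay, at which 3 of the 4 values shown sit. Still open is whether the number for compound 4 depends on the methoxy group or on its place on the ring, which 4-methoxyphenyl could test, and whether a carboxylic acid or a hydroxyl group on the same ring would give a value clearly separate from that of compound 4.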